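This account rests on a few compounds, and the source may have more. Where it says the series, first, only, none or still open, it means among the compounds named here.

Of the compounds shown here, two built on a shared core have so far been tested in an ADME assay on MCF7 cells (Homo sapiens) for cytotoxicity, read by CellTiter-Glo, with a stated time of 24 h; a lower number here means a stronger inhibitor of growth, a higher number a weaker inhibitor of growth. Compound 1 `CC1=C(C(=O)OCc2ccccc2)C(c2ccc(Cl)cc2Cl)NC(=O)N1CCCC(=O)OCc1ccccc1` gives only a limit of the assay there, > 100000 nM. Compound 2 `CC1=C(C(=O)OCc2ccccc2)C(c2ccc(Cl)cc2Cl)NC(=O)N1CCCC(=O)OCC#N` likewise gives only a limit, > 100000 nM. The step that the two limits leave unreadable from compound 1 to compound 2 therefore cannot be read, and compound 2 stands at the edge of what the assay reports rather than at a number. Compound 3 `COC(=O)CCCCN1C(=O)NC(c2ccc(Cl)cc2Cl)C(C(=O)OCc2ccccc2)=C1C` has not yet been measured; it differs from compound 2 by (methoxycarbonyl)methyl in place of cyanomethoxycarbonyl on a saturated chain carbon, three bonds along the chain from an amide-type nitrogen in a ring. Going by the values given here, the one measured step bears on this change, and it is unreadable; both measured values sit at the limit of > 100000 nM in this assay, at which 2 of the 2 values shown sit. No step beyond the usual scatter is therefore expected in this assay in either direction, and compound 3 is expected to return only a limit again. The step that the limit leaves unreadable from compound 2 to compound 3 is expected to be flat. Compound 3 is estimated at 150000 nM, between 80000 nM and 500000 nM.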

Compound 3, concentration for 50% growth inhibition: > 100000 nM
Compound 3: no number, only a limit; the forecaster's own chance of this, stated with the estimate: 85%; the middle value is on the limit's open side.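

Compound 1, compound 2 and compound 3 each give only a limit in this assay, so no step among them can be read: the limit of > 100000 nM in this assay, at which 3 of the 3 values shown sit.

The compounds shown leave open whether any change to the ester chain or the shared core would give an actual number in this assay.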